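From 2-hydroxyethyl to hydroxy on compound 3

A few compounds are considered here, and "the series" means these few. Any claim that something is new, unique, unknown or untested is made for them only; others in the source may bear on it.

In an ADME assay on CV-1 cells (Chlorocebus aethiops) for cytotoxicity (a lower number here means that less compound is tolerated, a higher number that more compound is tolerated), compound 3 `Nc1nc(F)cc2c1ncn2[C@@H]1C[C@H](CCO)[C@@H](O)[C@H]1O` gives > 338000 nM as its reading, and this is a limit, not a number. Compound 2 `Nc1nc(F)cc2c1ncn2[C@@H]1C[C@H](CO)[C@@H](O)[C@H]1O` gives > 355000 nM as its reading, which is also a limit. Compound 1 `Nc1nc(F)cc2c1ncn2[C@@H]1C=C(CCO)[C@@H](O)[C@H]1O` gives > 100000 nM as its reading, again a limit. Going by the values given here, none of these three compounds has yet produced an actual half-maximal concentration in this assay so far.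

Compound 4 `Nc1nc(F)cc2c1ncn2[C@@H]1C[C@H](O)[C@@H](O)[C@H]1O` differs from compound 3 in one place: on a saturated ring carbon, hydroxy stands in place of 2-hydroxyethyl hydroxy in place of 2-hydroxyethyl on a saturated ring carbon while the rest of the molecule stays the same.

The closest measured change is a step that the two limits leave unreadable from compound 2 to compound 3 and it alters the same chain, so it gives no size to carry over. Among the compounds with values here, with no measured step pointing either way, no shift beyond the usual scatter is expected, and compound 4 will probably also be reported only as a limit. The estimate amounts to an at least 1.1-fold lower number from compound 3 to compound 4 (0.05 log units; that floor lies within the scatter) as the expected change. For compound 4 the estimated value is 300000 nM with an expected range from 120000 nM to 400000 nM overall.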

Compound 4, half-maximal cytotoxic concentration: > 100000 nM
Compound 4 was reported as a limit; the forecaster's own chance of this, stated with the estimate: 85%; the middle value does not contradict the limit.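

In this assay compound 4 gives > 100000 nM, which is again a limit and not a number. With limits on both sides, the steps from compound 2 and compound 3 to compound 4 cannot be read. The compounds shown leave open whether exchanging hydroxy, hydroxymethyl and 2-hydroxyethyl changes the cytotoxic concentration at all.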